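The source may hold more compounds than are shown below. What is called first, only, known or untested is meant among the compounds shown, and "the series" means these compounds.

This study concerns a small set of compounds sharing one core, each carrying a sulfonyl group on an aromatic nitrogen with a different aromatic ring attached to the sulfonyl sulfur. Compound 1 `COc1ccc(-c2cc(=O)c3c(OC)cc(OC)cc3n2S(=O)(=O)c2ccc([N+](=O)[O-])cc2)cc1` and compound 2 `COc1ccc(-c2cc(=O)c3c(OC)cc(OC)cc3n2S(=O)(=O)c2ccc(C)c([N+](=O)[O-])c2)cc1` belong to the set, but for neither of them was a result reported: in a functional assay on SEM cells (Homo sapiens) for antiproliferative activity, with a stated time of 72 h (on this read-out higher numbers stand for an effect only at larger amounts of compound and lower numbers for an effect already at smaller amounts), compound 1 gives "not determined" (no result reported), and compound 2 gives "not determined" (no result reported). Among the compounds with values here, compound 3 `COc1ccc(-c2cc(=O)c3c(OC)cc(OC)cc3n2S(=O)(=O)c2ccc(C#N)cc2)cc1` is the only member with a number: in this assay compound 3 gives 1300 nM. Compound 3 therefore stands alone, with nothing to compare it against.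

Compound 4 `COc1ccc(-c2cc(=O)c3c(OC)cc(OC)cc3n2S(=O)(=O)c2c(F)c(F)c(F)c(F)c2F)cc1` is the compound not yet measured. It differs from compound 3 in one place: 2,3,4,5,6-pentafluorophenyl in place of 4-cyanophenyl on a sulfonyl sulfur. Within the data shown here, no step between two measured compounds exists here, so the size and direction of this change cannot be read from any pair. With a single measured point, the expectation for compound 4 is that its value will not move beyond the usual scatter from that of compound 3, and the step from compound 3 to compound 4 is estimated as a 1.2-fold higher number from compound 3 to compound 4 (0.06 log units; within the scatter). For compound 4 the estimate in this assay is 1500 nM, expected between 400 nM and 6000 nM.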

Compound 4, half-maximal effective concentration: 3900 nM
For compound 4 the middle estimate is 2.6-fold (0.41 log units) below the measured one; low and high end bracket the measured number.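

In this assay the exchange of 4-cyanophenyl for 2,3,4,5,6-pentafluorophenyl on a sulfonyl sulfur gives a 3.0-fold higher number from compound 3 to compound 4 (0.48 log units; beyond the scatter) and so a larger amount of compound is needed for the same effect. Within the data shown here, with only one number available before, nothing could be said about this position; now it is clear that the ring on the sulfur can shift the read-out, and that of these two rings, 4-cyanophenyl goes with the smaller number. Nothing measured here explains what in this exchange produces the step.

Among these compounds, compound 1 and compound 2 have no number, so no steps involving them can be read. On these data alone, it remains open how a phenyl ring carrying an amine or a carboxylic acid, or a longer alkyl chain in place of the ring, would behave on this sulfur.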